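The source may hold more compounds than are shown below. What is called first, only, known or untested is meant among the compounds shown, and "the series" means these compounds.

Of the compounds shown here, three sharing one core have been measured in a functional assay on Shh Light II cells (Mus musculus) for inhibition, read by a luciferase reporter; a higher number here means a weaker inhibitor, a lower number a stronger inhibitor. Compound 1 `C[C@H]1C[C@H](c2nc(-c3ccc4ccccc4n3)no2)CCN1C(=O)Nc1ccccc1Cl` gives 900 nM, compound 2 `O=C(NC1CCCCC1)N1CCN(c2nc(-c3ccc4ccccc4n3)no2)CC1` gives 53 nM, and compound 3 `CC(=O)N1CCC(NC(=O)N2CCC(c3nc(-c4ccc5ccccc5n4)no3)CC2)CC1` gives 500 nM. Compound 3 thus holds the second highest number of the three: it lies within the scatter of compound 1, while compound 2 sits well below it, beyond the scatter. Compound 4 `O=C(OCc1ccccc1)N1CCC(c2nc(-c3ccc4ccccc4n3)no2)CC1` differs from compound 3 in one place: benzyloxy in place of (1-acetylpiperidin-4-yl)amino on a carbonyl carbon. Among the compounds with values here, no measured pair shows this same change, so its size can only be estimated. A modest step toward a lower number is expected, a 2.0-fold lower number from compound 3 to compound 4 (0.30 log units; within the scatter), a guess that rests on compound 2 reaching 53 nM with a different group on the same carbonyl carbon. Compound 4 is expected to give about 250 nM, within a range from 80 nM to 800 nM.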

Compound 4, half-maximal inhibitory concentration: > 2500 nM
Compound 4 ended at the assay's limit; the forecaster's own chance of this, stated with the estimate: 5%; middle value at least 10-fold (1.00 log units) from the limit.
By their numbers in this assay, from the lowest: compound 2; then compounds 3 and 1 (each within the scatter of the next). At a limit, above all of these: compound 4.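

In this assay compound 4 sits at > 2500 nM, which is a limit of the assay and not a number. Placing benzyloxy in place of (1-acetylpiperidin-4-yl)amino on this carbonyl carbon gives an at least 5.0-fold higher number from compound 3 to compound 4 (0.69 log units; beyond the scatter), so the group held there can matter beyond the scatter. The full size of this step cannot be read, since the measurement stops at a limit: the limit of > 2500 nM in this assay, at which 1 of the 4 values shown sits.

Going by these compounds, it remains open whether a benzylamino group on the same carbonyl carbon would read like compound 3 or like compound 4.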